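Second chloro on the aryl ring: outlook for compound 3

A few compounds are considered here, and "the series" means these few. Any claim that something is new, unique, unknown or untested is made for them only; others in the source may bear on it.

Two members of the series have been run in a functional assay on U-87MG ATCC cells for antiproliferative activity against U-87 MG (Homo sapiens), read by MTT assay, with a stated time of 48 h, tested at 50 uM; a higher number here means a weaker effect of the compound at the concentration tested, a lower number a stronger effect. Compound 1 `COc1ccc(-c2nc(C)c(C(=O)CSc3nc(-c4ccc(Cl)c(Cl)c4)c(C#N)c(=O)[nH]3)s2)cc1` gives 78.4% in this assay. Compound 2 `Cc1nc(-c2ccccc2)sc1C(=O)CSc1nc(-c2cccc(Cl)c2)c(C#N)c(=O)[nH]1` gives 50.6% in this assay, the lowest of the two numbers; the nearest number, that of compound 1, lies higher by an amount beyond the scatter. Compound 1 and compound 2 differ in more than one place, so no single step can be read from that pair, and only what the two values show is stated here.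

Compound 3 `Cc1nc(-c2ccccc2)sc1C(=O)CSc1nc(-c2ccc(Cl)c(Cl)c2)c(C#N)c(=O)[nH]1` has not yet been measured in this assay. It differs from compound 2 in one place: chloro in place of hydrogen on an aromatic carbon. Going by the values given here, no step of exactly this kind has been measured. Compound 3 and compound 1 carry the same 3,4-dichlorophenyl group but differ in the group on the shared core; in this assay compound 1 gives 78.4%, the weaker of the two numbers seen so far. The step from compound 2 to compound 3 is therefore expected to go toward a weaker effect, of moderate size, a number 12.4 percentage points higher from compound 2 to compound 3 (beyond the scatter), probably beyond the scatter. Compound 3 is estimated at 63%, with a range from 46% to 80%.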

Compound 3, a percentage reported as activity, at one concentration (the size of the read-out at that concentration, not a potency): 75.3%
Estimate against measurement, compound 3: 12.3 percentage points below; measured number inside the range.
By their numbers in this assay, from the lowest: compound 2; then compounds 3 and 1 (each within the scatter of the next).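

In this assay, going by these compounds alone, the change from 3-chlorophenyl to 3,4-dichlorophenyl gives the first single-place reading at this aromatic carbon, ortho to a chloro group: a number 24.7 percentage points higher from compound 2 to compound 3 (beyond the scatter), so adding chloro here weakens the effect at the concentration tested. With the 3,4-dichlorophenyl group held constant, hydrogen in place of methoxy on an aromatic carbon gives a number 3.1 percentage points lower from compound 1 to compound 3 (within the scatter), which does not separate the two compounds, so the gap seen earlier between compound 1 and compound 2 goes with the second chloro in these compounds rather than with the methoxy group. Nothing available gives a reason for the size or direction of the chloro step.

From the compounds shown here alone, whether the weaker effect is specific to chloro at this carbon remains open, since a fluoro, a methyl, a methoxy or an amine at the same place on the 3-chlorophenyl ring could read differently. The compounds shown also leave open whether the first chloro matters, a question that a plain phenyl or a 4-chlorophenyl group on the shared core would address.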